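This account rests on a few compounds, and the source may have more. Where it says the series, first, only, none or still open, it means among the compounds named here.

Compound 3 `Cc1ccc(N(C(=O)c2ccccc2C)C(=S)OCCN2C(=O)c3ccccc3C2=O)cc1` sits at the ceiling of an ADME assay on MT4 cells (Homo sapiens) for cytotoxicity, read by MTT assay; on this read-out higher numbers stand for lower toxicity in this test and lower numbers for higher toxicity in this test: its value > 100000 nM is a limit of the assay, not a number. Compound 1 `Cc1ccccc1C(=O)N(C(=S)OCCN1C(=O)c2ccccc2C1=O)c1ccc(Cl)cc1` gives 21000 nM in this assay. Compound 2 `O=C1c2ccccc2C(=O)N1CCOC(=S)N(C(=O)c1cccnc1Cl)c1ccc(Br)cc1` also reaches only a limit, > 100000 nM. Among the compounds with values here, the single measured step, an at least 4.7-fold higher number from compound 1 to compound 3 (0.67 log units; beyond the scatter), moves from a number onto the limit, and the limit of > 100000 nM in this assay, at which 2 of the 3 values shown sit, shows how much of the series already sits there.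

Compound 4 `Cc1ccc(N(C(=O)c2c(F)cccc2F)C(=S)OCCN2C(=O)c3ccccc3C2=O)cc1` is the next change: 2,6-difluorophenyl in place of 2-methylphenyl on a carbonyl carbon. Within the data shown here, no measured step touches the group on the carbonyl carbon, so the one step in hand, which concerns the chloro and methyl on the aromatic carbon, does not bear on this change directly; it only shows that compound 3 already stands at the limit. The expectation for this assay is therefore no step beyond the scatter, a number no higher from compound 3 to compound 4 (the limit leaves the size open), with compound 4 most likely returning a limit again. Compound 4 is estimated at 100000 nM, within 30000 nM to 200000 nM.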

Compound 4, half-maximal cytotoxic concentration: 65000 nM
Beside the measured number, compound 4's estimate is 1.5-fold (0.19 log units) above it; the measured number falls inside the stated range.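

The group on the carbonyl carbon now has its first measured step in this assay, with 2,6-difluorophenyl in place of 2-methylphenyl: an at least 1.5-fold lower number from compound 3 to compound 4 (0.18 log units; that floor lies within the scatter). Compound 4 gives 65000 nM, so a change at this place can return a number rather than a limit, with the rest of the structure kept. The true size of the step remains unknown because one end of it is a limit of the assay, and that limit still holds much of the series: the limit of > 100000 nM in this assay, at which 2 of the 4 values shown sit.

Open, from the compounds shown here alone, is whether 2,6-difluorophenyl would read the same with chloro in place of methyl on the aromatic carbon, the pairing that would connect it to compound 1. Also open, going by these compounds, is how a non-aromatic group on the carbonyl carbon, such as cyclohexyl or a longer alkyl chain, would read.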